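The source may hold more compounds than are shown below. What is called first, only, known or untested is meant among the compounds shown, and "the series" means these compounds.

For the measured compounds named here, compound 2 `CC(=O)NCCS(=O)(=O)NC(=O)c1ccc(Nc2nc(NC3(c4ccc(Cl)cc4)CC3)nc(OCC(F)(F)F)n2)cc1` stands at the top of the two numbers so far in an ADME assay on microsomes from liver (Homo sapiens) for metabolic stability, with a stated time of 10 min (a higher number here means that more of the compound is left, a lower number that less of the compound is left), where compound 2 gives 95%; compound 1 `CC(C)NCCS(=O)(=O)NC(=O)c1ccc(Nc2nc(NC3(c4ccc(Cl)cc4)CC3)nc(OCC(F)(F)F)n2)cc1` gives 89%, and the change a number 6 percentage points higher from compound 1 to compound 2 (within the scatter) lies within the scatter. Compound 3 `COC(=O)NCCS(=O)(=O)NC(=O)c1ccc(Nc2nc(NC3(c4ccc(Cl)cc4)CC3)nc(OCC(F)(F)F)n2)cc1` is the next variation at the same amine nitrogen: methoxy in place of methyl on a carbonyl carbon. Going by the values given here, the only step that bears on this change, acetyl replacing isopropyl, produced a number 6 percentage points higher from compound 1 to compound 2 (within the scatter), so no shift beyond the scatter is expected for compound 3 in this assay, an expected step of a number 2 percentage points lower from compound 2 to compound 3 (within the scatter). Compound 3 is therefore estimated at 93%, ranging from 82% to 100%.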

Compound 3, percent of the compound remaining: 90%
The estimate for compound 3 lay 3 percentage points above the measured number; the range from low to high includes it.
By their numbers in this assay, from the lowest: compounds 1, 3 and 2 (each within the scatter of the next).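

In this assay, methoxy in place of methyl on the carbonyl carbon gives (a number 5 percentage points lower from compound 2 to compound 3 (within the scatter)), and methoxycarbonyl in place of isopropyl on the amine nitrogen gives (a number 1 percentage points higher from compound 1 to compound 3 (within the scatter)). Isopropyl, acetyl and methoxycarbonyl at this nitrogen therefore all lie within the scatter of one another, and extending the acetyl to methoxycarbonyl separates nothing. Nothing available explains this reading. Still open, going by these compounds, is whether a carboxylic acid, a cyclic amine or a longer chain at this nitrogen would move the number beyond the scatter.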